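The source may report more compounds than this note shows. Statements on the series, on what has been measured and on what is new or still open speak of the compounds shown alone.

Measured compounds:
compound 1 `O=C(Nc1ccccc1)c1cc2ccccc2oc1=O`, 760 nM
compound 2 `COc1ccc(NC(=O)c2cc3ccccc3oc2=O)cc1`, 820 nM
compound 3 `CSc1ccc(NC(=O)c2cc3ccccc3oc2=O)cc1`, 2840 nM

All three share one core and differ only in one group on the outer ring. In an in vitro assay on BTI-TN-5B1-4 cells for inhibition of Amine oxidase [flavin-containing] B (Homo sapiens), read by fluorescence (on this read-out lower numbers stand for stronger inhibition and higher numbers for weaker inhibition), compound 1 gives 760 nM, at the low end of the three numbers, with compound 2 within the scatter of it (a 1.1-fold higher number from compound 1 to compound 2 (0.03 log units; within the scatter)) and compound 3 beyond it (a 3.7-fold higher number from compound 1 to compound 3 (0.57 log units; beyond the scatter)). Compound 4 `CS(=O)(=O)c1ccc(NC(=O)c2cc3ccccc3oc2=O)cc1` is unmeasured; it carries methylsulfonyl in place of hydrogen on an aromatic carbon. The steps bearing on this are the unchanged number for methoxy, the weakening for methylsulfanyl, and a 3.5-fold higher number from compound 2 to compound 3 (0.54 log units; beyond the scatter). A larger sulfur-bearing group is therefore expected to weaken, in a modest step. Compound 4 is expected near 3000 nM, within 1000 nM to 9000 nM, an expected step of a 3.9-fold higher number from compound 1 to compound 4 (0.60 log units; beyond the scatter).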

Compound 4, half-maximal inhibitory concentration: 1.4 nM
Compound 4: middle estimate off by 2100-fold (3.33 log units), on the high side; measured number outside the range, below it.
By their numbers in this assay, from the lowest: compound 4; then compounds 1 and 2 (each within the scatter of the next); then compound 3.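

Methylsulfonyl, on an aromatic carbon para to a large group, gives a 540-fold lower number from compound 1 to compound 4 (2.73 log units; beyond the scatter) in place of hydrogen, so this position can carry a far larger change in the number than the earlier compounds showed. Replacing methoxy gives a 590-fold lower number from compound 2 to compound 4 (2.77 log units; beyond the scatter) and replacing methylsulfanyl gives a 2000-fold lower number from compound 3 to compound 4 (3.31 log units; beyond the scatter) here, so the two sulfur-bearing groups do not act alike at this position. Nothing shown here explains this gain.

From the compounds shown here alone, whether the gain belongs to methylsulfonyl alone remains open. A sulfonamide, a nitrile or a carboxylic acid at this position could help settle that.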